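Substituent swaps at one aromatic carbon: cytotoxicity notes

The source may hold more compounds than are shown below. What is called first, only, known or untested is meant among the compounds shown, and "the series" means these compounds.

Measured so far in a toxicity assay on CCRF-CEM cells (Homo sapiens) for cytotoxicity; a higher number here means that more compound is tolerated, a lower number that less compound is tolerated:
compound 1 `Nc1cccc2c1nc(-c1c(F)cccc1F)n2Cc1c(F)cccc1F`, 26.3 uM
compound 2 `N#Cc1cccc2c1nc(-c1c(F)cccc1F)n2Cc1c(F)cccc1F`, 26.7 uM
compound 3 `N=C(NO)c1cccc2c1nc(-c1c(F)cccc1F)n2Cc1c(F)cccc1F`, 23.1 uM

Compound 1 stands second highest of the three numbers in this assay; compound 2 is nearest, compound 3 furthest, and both differences lie within the scatter, so the three compounds cannot be told apart on this read-out.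

Compound 4 `O=Cc1cccc2c1nc(-c1c(F)cccc1F)n2Cc1c(F)cccc1F` has not been measured. It differs from compound 1 in one place: formyl in place of amino on an aromatic carbon.

Going by the values given here, two measured steps touch the same aromatic carbon. a 1.0-fold higher number from compound 1 to compound 2 (0.01 log units; within the scatter). a 1.1-fold lower number from compound 1 to compound 3 (0.06 log units; within the scatter). Between the two changed compounds, a 1.2-fold lower number from compound 2 to compound 3 (0.06 log units; within the scatter). Every replacement tried at this carbon, whether by a group of 2 heavy atoms or of 4, left the number where it was. A formyl group is one more such replacement, and nothing in the series points to a different outcome, so no step beyond the scatter is expected: a 1.1-fold lower number from compound 1 to compound 4 (0.02 log units; within the scatter).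

Compound 4 is therefore estimated at 25 uM in this assay, with an expected range from 12 uM to 50 uM.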

Compound 4, half-maximal toxic concentration: 0.82 uM
For compound 4 the middle estimate is 30-fold (1.48 log units) above the measured one; the whole stated range lies above it.
By their numbers in this assay, from the lowest: compound 4; then compounds 3, 1 and 2 (each within the scatter of the next).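

In this assay this aromatic carbon proves sensitive to what it carries: a 32-fold lower number from compound 1 to compound 4 (1.51 log units; beyond the scatter), a 33-fold lower number from compound 2 to compound 4 (1.51 log units; beyond the scatter) and a 28-fold lower number from compound 3 to compound 4 (1.45 log units; beyond the scatter), so the flat picture from compounds 1, 2 and 3 held for those three groups only, not for the position as a whole. Group size does not sort the series, since formyl and cyano both count 2 heavy atoms and still sit on opposite sides of the large step. Nothing available on these compounds bears on what lies behind the step.

Open, going by these compounds, is whether the step belongs to the formyl group alone or to carbonyl groups in general. An acetyl group, a carboxylic acid or a primary amide on the same carbon, and a hydroxymethyl group as the non-carbonyl counterpart, would separate these readings.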